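Swapping a but-1-en-1-yl chain for hexyl

A few compounds are considered here, and "the series" means these few. Any claim that something is new, unique, unknown or untested is made for them only; others in the source may bear on it.

compound 1 `CCCC/C=C/c1c(C)cc(C)c2[n+]1CC(C)C=C2` gives 370 nM
compound 2 `CC/C=C/c1c(C)cc(C)c2[n+]1CC(C)C=C2` gives 2000 nM
compound 3 `CCCCCCCCCC/C=C/c1c(C)cc(C)c2[n+]1CC(C)C=C2` gives 52 nM

In a functional assay on HeLa S3 cells (Homo sapiens) for cytotoxicity, read by MTT assay, with a stated time of 48 h (a higher number here means a weaker inhibitor, a lower number a stronger inhibitor), compound 2 gives 2000 nM as the highest of these three numbers. Compound 4 `CCCCCCc1c(C)cc(C)c2[n+]1CC(C)C=C2` has hexyl in place of but-1-en-1-yl on an aromatic carbon. Within the data shown here, two measured steps bear on this change. Shortening the chain gave a modest step (a 5.4-fold higher number from compound 1 to compound 2 (0.73 log units; beyond the scatter)), and lengthening it gave a large one (a 38-fold lower number from compound 2 to compound 3 (1.59 log units; beyond the scatter)). In these three compounds, longer chains go with lower numbers, and none goes against that. Among the measured compounds shown here, compound 4 also loses the double bond, and no measured pair shows what that does. A modest step towards a lower number is therefore expected (a 4.0-fold lower number from compound 2 to compound 4 (0.60 log units; beyond the scatter)). The expected value for compound 4 is 500 nM (estimated range 150 nM to 1600 nM).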

Compound 4, half-maximal inhibitory concentration: 470 nM
Compound 4: the middle estimate sits 1.1-fold (0.03 log units) above what was measured; measured number inside the range.
By their numbers in this assay, from the lowest: compound 3; then compounds 1 and 4 (each within the scatter of the next); then compound 2.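

In this assay, replacing hex-1-en-1-yl with hexyl on this aromatic carbon gives a 1.3-fold higher number from compound 1 to compound 4 (0.10 log units; within the scatter), so at this chain length, losing the double bond leaves the number within the scatter. The other new step, a 4.3-fold lower number from compound 2 to compound 4 (0.63 log units; beyond the scatter), shows that hexyl on this carbon also differs from the shorter but-1-en-1-yl by a modest amount. No measured evidence here explains either step.

On these data alone, whether losing the double bond matters as little in a longer chain stays open. So does what an amine or a carboxylic acid would do in place of hexyl on this aromatic carbon.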